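The source may hold more compounds than are shown below. What is called first, only, known or untested is meant among the compounds shown, and "the series" means these compounds.

The measured compounds:
compound 1 `Cc1c(O)ccc2cc(-n3cc(-c4ccccc4)nn3)c(=O)oc12`, giving 25200 nM in a functional assay on MCF7 cells (Homo sapiens) for antiproliferative activity; a higher number here means a weaker inhibitor, a lower number a stronger inhibitor;
compound 2 `Cc1ccc(-c2cn(-c3cc4ccc(O)c(C)c4oc3=O)nn2)cc1`, giving 23200 nM in this assay;
compound 3 `Cc1c(O)ccc2cc(-n3cc(-c4ccc(F)cc4F)nn3)c(=O)oc12`, giving 33500 nM in this assay.

The three share one core and differ only in the aryl group carried on the five-membered aromatic ring with three nitrogens. Compound 3 stands highest of the three numbers, but a 1.3-fold higher number from compound 1 to compound 3 (0.12 log units; within the scatter) and a 1.4-fold higher number from compound 2 to compound 3 (0.16 log units; within the scatter), so all three sit within the scatter of one another and no order among them can be stated.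

Compound 4 `COc1ccc(-c2cn(-c3cc4ccc(O)c(C)c4oc3=O)nn2)cc1` differs from compound 3 by 4-methoxyphenyl in place of 2,4-difluorophenyl on an aromatic carbon. The measured steps that bear on this change all alter the same aryl group: a 1.1-fold lower number from compound 1 to compound 2 (0.04 log units; within the scatter), a 1.3-fold higher number from compound 1 to compound 3 (0.12 log units; within the scatter) and a 1.4-fold higher number from compound 2 to compound 3 (0.16 log units; within the scatter). None of them moved the number beyond the scatter. For the measured compounds named here, the entering 4-methoxyphenyl brings one hydrogen-bond acceptor that no measured compound carries, so this feature is untested, but nothing among the aryl variations seen so far suggests a change in this assay beyond the scatter.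

Compound 4 is therefore expected to give about 25000 nM in this assay, within a range of 10000 nM to 60000 nM. This corresponds to an expected step of a 1.3-fold lower number from compound 3 to compound 4 (0.13 log units; within the scatter), which would lie within the scatter.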

Compound 4, half-maximal inhibitory concentration: > 100000 nM
Compound 4 was reported as a limit; the forecaster's own chance of this, stated with the estimate: 10%; middle value at least 4.0-fold (0.60 log units) away from the limit.
By their numbers in this assay, from the lowest: compounds 2, 1 and 3 (each within the scatter of the next). At a limit, above all of these: compound 4.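

The value of compound 4 in this assay is a limit and not a number: the limit of > 100000 nM in this assay, at which 1 of the 4 values shown sits.

It shows that the aryl group on this aromatic carbon, next to the ring nitrogen, is less free to vary than the phenyl, 4-methylphenyl and 2,4-difluorophenyl groups had suggested: 4-methoxyphenyl in place of 2,4-difluorophenyl gives an at least 2.9-fold higher number from compound 3 to compound 4 (0.47 log units; beyond the scatter), methoxy in place of methyl gives an at least 4.3-fold higher number from compound 2 to compound 4 (0.63 log units; beyond the scatter), and methoxy in place of hydrogen gives an at least 3.9-fold higher number from compound 1 to compound 4 (0.59 log units; beyond the scatter). All three steps lie beyond the scatter, whereas the three earlier compounds stay within the scatter of one another, and the entering 4-methoxyphenyl carries a hydrogen-bond acceptor that none of those aryl groups has.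

The compounds shown cannot tell whether the oxygen of the methoxy, its place on the phenyl ring or the larger size of that group than methyl or hydrogen accounts for the step, and the limit leaves the true size of the step unknown. As far as these compounds go, a hydroxyl, an ethoxy or an amine in place of the methoxy, or a methoxy elsewhere on the phenyl ring, remains open.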